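Pyrimidinyl ether variant of the isatin sulfonamide series

The source may report more compounds than this note shows. Statements on the series, on what has been measured and on what is new or still open speak of the compounds shown alone.

Compound 1 `O=C1C(=O)N(Cc2ccc(F)cc2)c2ccc(S(=O)(=O)N3CCC[C@H]3COc3ccc(F)cc3)cc21` carries a 4-fluorophenyl ether on the pyrrolidine arm of the shared core. In an assay on isolated protein for inhibition of Caspase-8 (Homo sapiens) (on this read-out lower numbers stand for an effect already at smaller amounts and higher numbers for an effect only at larger amounts of compound), compound 1 gives > 5000 nM, which is a limit of the assay and not a number. Compound 2 `O=C1C(=O)N(Cc2ccc(F)cc2)c2ccc(S(=O)(=O)N3CCC[C@H]3COC3CCOCC3)cc21` puts an oxan-4-yl in place of that group. In this assay compound 2 gives > 5000 nM, likewise a limit of the assay. The step that the two limits leave unreadable from compound 1 to compound 2 therefore cannot be read in either direction, since both values sit at the limit of > 5000 nM in this assay, at which 2 of the 2 values shown sit. Compound 2 thus stands at the limit of this assay, with no measured number that would rank it against compound 1.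

Compound 3 `O=C1C(=O)N(Cc2ccc(F)cc2)c2ccc(S(=O)(=O)N3CCC[C@H]3COc3ccncn3)cc21` is the next point: pyrimidin-4-yl in place of oxan-4-yl on an oxygen on a saturated carbon. For the measured compounds named here, no measured step bears directly on this change; the only step in hand, from compound 1 to compound 2, is unreadable because its two values rest on (the limit of > 5000 nM in this assay, at which 2 of the 2 values shown sit). In this assay the step that the limit leaves unreadable from compound 2 to compound 3 is accordingly expected to be none beyond the scatter, with another limit the likeliest outcome. Compound 3 is estimated at 8000 nM, within a range from 3000 nM to 30000 nM.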

Compound 3, half-maximal effective concentration: > 5000 nM
Compound 3: a limit, no number; the forecaster's own chance of this, stated with the estimate: 80%; the middle value does not contradict the limit.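

The steps among compound 1, compound 2 and compound 3 cannot be read in this assay, because all three values are limits of the assay and not numbers: the limit of > 5000 nM in this assay, at which 3 of the 3 values shown sit.

The compounds shown leave open how the 4-fluorophenyl, oxan-4-yl and pyrimidin-4-yl ethers rank against one another in this assay.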